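Heteroaryl replacements on the shared core

A few compounds are considered here, and "the series" means these few. Any claim that something is new, unique, unknown or untested is made for them only; others in the source may bear on it.

Measured compounds:
compound 1 `CCC(C)(C)Cc1c[nH]c(CCc2ccc(-c3cccc(C)n3)cc2)n1` gives 6.3 nM in an in vitro assay on CHO cells for displacement of a labelled ligand from Bombesin receptor subtype-3 (Homo sapiens), read by scintillation counting, with a stated time of 2 h; a lower number here means a stronger inhibitor, a higher number a weaker inhibitor
compound 2 `CCC(C)(C)Cc1c[nH]c(CCc2ccc(-c3ccc(F)cn3)cc2)n1` gives 19 nM in this assay
compound 3 `CCC(C)(C)Cc1c[nH]c(CCc2ccc(-c3cnsc3)cc2)n1` gives 10 nM in this assay

Compound 3 stands second highest of the three numbers, with a 1.6-fold higher number from compound 1 to compound 3 (0.20 log units; within the scatter) and a 1.9-fold lower number from compound 2 to compound 3 (0.28 log units; within the scatter) both within the scatter. The next compound, compound 4 `CCC(C)(C)Cc1c[nH]c(CCc2ccc(-n3cncn3)cc2)n1`, is unmeasured; its change is 1H-1,2,4-triazol-1-yl in place of 1,2-thiazol-4-yl on an aromatic carbon. Within the data shown here, the only step beyond the scatter among the measured heteroaryl swaps is a 3.0-fold higher number from compound 1 to compound 2 (0.48 log units; beyond the scatter), which was modest; the other two swaps gave nothing beyond the scatter. A further heteroaryl exchange at this place is therefore expected to move this assay little, if at all. Compound 4 is expected near 15 nM, with a range of 5 nM to 45 nM. The expected step is a 1.5-fold higher number from compound 3 to compound 4 (0.18 log units; within the scatter), within the scatter.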

Compound 4, half-maximal inhibitory concentration: 340 nM
Beside the measured number, compound 4's estimate is 23-fold (1.36 log units) below it, and the stated range ends below it.
By their numbers in this assay, from the lowest: compounds 1, 3 and 2 (each within the scatter of the next, the first and the last beyond it); then compound 4.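

This position does tolerate some heteroaryl exchange, but not all of it: in this assay the 1H-1,2,4-triazol-1-yl group gives a 34-fold higher number from compound 3 to compound 4 (1.53 log units; beyond the scatter) and an 18-fold higher number from compound 2 to compound 4 (1.25 log units; beyond the scatter) and a 54-fold higher number from compound 1 to compound 4 (1.73 log units; beyond the scatter) as large losses, unlike any earlier swap. Compound 3 and compound 4 carry five-membered aromatic rings of equal heavy-atom count, so ring size and heavy-atom count alone do not set the number here. Nothing available accounts for the loss.

Open, from the compounds shown here alone, is whether the third ring nitrogen or the attachment through nitrogen drives it. A pyrazol-1-yl or imidazol-1-yl group at this place would bear on that question.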